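The source may hold more compounds than are shown below. What is called first, only, known or untested is meant among the compounds shown, and "the series" means these compounds.

Measured so far:
compound 1 `CN1CC(=O)N(Cc2ccc(C(=O)NO)cc2)C1=O` gives 119 nM
compound 2 `CC1(c2ccccc2)NC(=O)N(Cc2ccc(C(=O)NO)cc2)C1=O` gives 74.9 nM

Both numbers come from an assay on isolated protein for inhibition of protein deacetylase HDAC6 (Homo sapiens), read by fluorescence, with stated times of 10 min and 2 h; a higher number here means a weaker inhibitor, a lower number a stronger inhibitor. Among the measured compounds shown here, compound 2 has the lower of the two numbers; the only other value, that of compound 1, lies within the scatter of it, so no order between the two can be read and neither is called the stronger inhibitor. For the measured compounds named here, the shared core, the benzohydroxamate side and the methylene link, is the same in both; they differ in more than one place, so no single step between measured compounds can be cut from them.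

Compound 3 `O=C(NO)c1ccc(CN2C(=O)NC(Cc3cccc4ccccc34)(c3ccccc3)C2=O)cc1` has not yet been measured. It differs from compound 2 in one place: naphthalen-1-yl in place of hydrogen on a saturated chain carbon bound to a saturated ring carbon. Going by the values given here, nothing among the measured pair calibrates this kind of enlargement on the saturated ring carbon, so the expectation rests on the observation that the two measured compounds, with quite different substitution at that part of the core, sit close together. The step of a 1.2-fold lower number from compound 2 to compound 3 (0.10 log units; within the scatter) is therefore expected to be small, at most a mild move toward a lower number. For compound 3 in this assay the estimate is 60 nM, with a range from 20 nM to 180 nM.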

Compound 3, half-maximal inhibitory concentration: 91.9 nM
The estimate for compound 3 lay 1.5-fold (0.19 log units) below the measured number; measured number inside the range.
By their numbers in this assay, from the lowest: compounds 2, 3 and 1 (each within the scatter of the next).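

The first single change readable in the series, methyl to (naphthalen-1-yl)methyl on the saturated ring carbon, gives a 1.2-fold higher number from compound 2 to compound 3 (0.09 log units; within the scatter) in this assay, and this step lies within the scatter. At this place, then, a group of 10 heavy atoms with 2 six-membered aromatic rings of carbon only enters without a readable change in the number, something the earlier pair could not show, since those two compounds differ in more than one place. No measurement at hand bears on the reason for this result.

The compounds shown leave open whether an amine or a carboxylic acid in place of naphthalen-1-yl on that saturated chain carbon would also stay within the scatter of compound 2, and whether a longer chain carrying naphthalen-1-yl would do the same. They also leave open how far this outcome depends on the phenyl group that compound 2 and compound 3 share on the saturated ring carbon, for instance whether it would hold with a hydrogen atom there instead.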